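This account rests on a few compounds, and the source may have more. Where it says the series, first, only, none or still open, it means among the compounds named here.

Measured compounds, all in a functional assay on A549 cells (Homo sapiens) for cytotoxicity, read by MTT assay, with a stated time of 48 h; on this read-out higher numbers stand for weaker inhibition and lower numbers for stronger inhibition:
- Compound 1, `COc1ccc(-c2c[nH]c(=O)n2-c2cc(OC)c(OC)c(OC)c2)cc1N`, gives > 50000 nM, a limit of the assay and not a number.
- Compound 2, `COc1ccc(-c2cn(C(=O)Nc3cc(OC)c(OC)c(OC)c3)c(=O)n2-c2cc(OC)c(OC)c(OC)c2)cc1`, gives > 50000 nM, again a limit and not a number.
- Compound 3, `COc1cc(-n2c(-c3ccc(Br)cc3)cn(C(C)=O)c2=O)cc(OC)c1OC`, gives 1300 nM.

Going by the values given here, compound 3 therefore stands as the only compound of the three with a measured number in this assay; the two others sit at the limit of > 50000 nM in this assay, at which 2 of the 3 values shown sit, so no step between measured compounds can be computed, and nothing can be said about the size of any change so far.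

Compound 4, `COc1ccc(-c2cn(C(C)=O)c(=O)n2-c2cc(OC)c(OC)c(OC)c2)cc1OC`, differs from compound 3 in one place: 3,4-dimethoxyphenyl in place of 4-bromophenyl on an aromatic carbon. The acetyl group and the trimethoxyphenyl group of compound 3 are kept.

Without any measured step to lean on, the expectation for compound 4 rests on compound 3 alone. The step from compound 3 to compound 4 in this assay is expected to be small, pointing toward weaker inhibition, and it may well stay within the usual scatter of repeated measurements; the expected step is a 2.3-fold higher number from compound 3 to compound 4 (0.36 log units; beyond the scatter). Compound 4 is thus estimated to give about 3000 nM in this assay, with a range from 800 nM to 15000 nM.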

Compound 4, half-maximal inhibitory concentration: > 50000 nM
Compound 4 gave a limit, no number; the forecaster's own chance of this, stated with the estimate: 20%; middle value at least 16-fold (1.22 log units) away from the limit.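

In this assay, going by these compounds alone, the exchange of 4-bromophenyl for 3,4-dimethoxyphenyl on this aromatic carbon gives the first step that can be read, an at least 38-fold higher number from compound 3 to compound 4 (1.58 log units; beyond the scatter), so this position is far from indifferent to the group it carries. As far as these compounds go, with the acetyl group and the trimethoxyphenyl group kept, this single exchange takes the series from a measured number to a limit of the assay, and compound 4 now joins the other compounds that have no number: the limit of > 50000 nM in this assay, at which 3 of the 4 values shown sit. No steps can be read among compound 1, compound 2 and compound 4, and the full size of the step from compound 3 remains unknown.

The two groups differ in more than one feature, so the compounds shown do not separate the departure of the bromine from the arrival of the two methoxy groups. From the compounds shown here alone, it remains open whether a 4-chlorophenyl, a 4-methylphenyl or a 4-methoxyphenyl group at this position, with the acetyl group kept, would hold a measurable number or fall to the same limit.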